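Bromine on a Shared Core: Expectation for Compound 4

The compounds below may be only part of what the source reports. "The series", "measured", "known", "first", "only" and "open" are said of these compounds alone.

Compound 1 `O=C1N=C(N2N=C(c3ccccc3)CC2c2ccccc2O)S/C1=C1/C(=O)Nc2ccccc21` is the starting point. In a functional assay on cells (Cancer cell lines, Homo sapiens) for cytotoxicity, read by sulforhodamine B assay, with a stated time of 48 h (on this read-out higher numbers stand for weaker inhibition of growth and lower numbers for stronger inhibition of growth), compound 1 gives 1990 nM. Compound 2 `O=C1N=C(N2N=C(c3ccccc3)CC2c2ccccc2O)S/C1=C1/C(=O)Nc2ccc(Br)cc21` differs from compound 1 by bromo in place of hydrogen on an aromatic carbon, and in this assay compound 2 gives 210 nM; the step is a 9.5-fold lower number from compound 1 to compound 2 (0.98 log units; beyond the scatter). Compound 3 `COc1ccc(C2CC(c3ccccc3)=NN2C2=NC(=O)/C(=C3\C(=O)Nc4ccccc43)S2)cc1` differs from compound 1 by 4-methoxyphenyl in place of 2-hydroxyphenyl on a saturated ring carbon, and in this assay compound 3 gives 1810 nM; the step of a 1.1-fold lower number from compound 1 to compound 3 (0.04 log units; within the scatter) shows that the two cores behave alike in this assay.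

Compound 4 `COc1ccc(C2CC(c3ccccc3)=NN2C2=NC(=O)/C(=C3\C(=O)Nc4ccc(Br)cc43)S2)cc1` has not yet been measured. It differs from compound 3 by bromo in place of hydrogen on an aromatic carbon. Within the data shown here, this is the same change as the one from compound 1 to compound 2, now made on the core of compound 3. Because a 9.5-fold lower number from compound 1 to compound 2 (0.98 log units; beyond the scatter) showed a clear gain when bromine entered the core of compound 1, a similar gain is expected on the core of compound 3, so the expected step for compound 3 is an 8.2-fold lower number from compound 3 to compound 4 (0.92 log units; beyond the scatter). Compound 4 is therefore estimated at 220 nM, with an expected range from 90 nM to 600 nM.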

Compound 4, concentration for 50% growth inhibition: 190 nM
Estimate against measurement, compound 4: 1.2-fold (0.06 log units) above; the measured number falls inside the stated range.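

In this assay, bromo in place of hydrogen on an aromatic carbon gives a 9.5-fold lower number from compound 3 to compound 4 (0.98 log units; beyond the scatter), and this step matches the one seen on the core of compound 1: the same change on two cores in this assay, a 9.5-fold lower number (0.98 log units; beyond the scatter) from compound 1 to compound 2 and a 9.5-fold lower number (0.98 log units; beyond the scatter) from compound 3 to compound 4, 1.0-fold (0.00 log units) apart, within the scatter of two such steps The exchange of 2-hydroxyphenyl for 4-methoxyphenyl, read on the brominated compounds, gives a 1.1-fold lower number from compound 2 to compound 4 (0.04 log units; within the scatter), a step within the scatter that also holds from one core to the other: the same change on two cores in this assay, a 1.1-fold lower number (0.04 log units; within the scatter) from compound 1 to compound 3 and a 1.1-fold lower number (0.04 log units; within the scatter) from compound 2 to compound 4, 1.0-fold (0.00 log units) apart, within the scatter of two such steps The bromo change therefore carried over between these two cores in this one cell assay, but two pairs cannot show that it would carry to a core with a different group on the saturated ring carbon, nor do they explain why the step has this size.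

The compounds shown hold only hydrogen or bromo at this place on the aromatic ring, so it remains open whether chloro, methoxy or an amine there would give a similar step. Going by these compounds, it also remains open whether the step would persist with a carboxylic acid on the phenyl group at the saturated ring carbon.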